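This account rests on a few compounds, and the source may have more. Where it says the series, first, only, none or still open, it means among the compounds named here.

Measured so far in a functional assay on HepG2 cells (Homo sapiens) for inhibition, read by MTT assay, with a stated time of 72 h; a lower number here means a stronger inhibitor, a higher number a weaker inhibitor:
compound 1, `O=C(OC1(C(=O)Nc2ccc([N+](=O)[O-])cc2)CCCCC1)c1ccc(C(F)(F)F)cc1`, 29.1 nM
compound 2, `COc1ccc(C(=O)OC2(C(=O)Nc3ccc([N+](=O)[O-])cc3)CCCCC2)cc1`, 57.1 nM
compound 3, `O=C(OC1(C(=O)Nc2ccc([N+](=O)[O-])cc2)CCCCC1)c1ccccc1`, 734 nM

Compound 3 gives the highest number of the three; the steps of a 25-fold higher number from compound 1 to compound 3 (1.40 log units; beyond the scatter) and a 13-fold higher number from compound 2 to compound 3 (1.11 log units; beyond the scatter) are both large, while a 2.0-fold higher number from compound 1 to compound 2 (0.29 log units; within the scatter) is not. Compound 4, `O=C(OC1(C(=O)Nc2ccc([N+](=O)[O-])cc2)CCCCC1)C(O)c1ccccc1`, differs from compound 3 by hydroxy(phenyl)methyl in place of phenyl on a carbonyl carbon. Going by the values given here, no measured step touches this position; the measured steps all alter a substituent on the aromatic ring of the ester part. Among the compounds with values here, they show only that changes in this part of the molecule can move the number a long way, without telling the direction here. For compound 4 no step beyond the scatter is therefore assumed, with a wide range, giving an expected 1.1-fold higher number from compound 3 to compound 4 (0.04 log units; within the scatter). Compound 4 is estimated at 800 nM, between 200 nM and 3500 nM.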

Compound 4, half-maximal inhibitory concentration: 7.7 nM
The estimate for compound 4 lay 100-fold (2.02 log units) above the measured number; the whole stated range lies above it.
By their numbers in this assay, from the lowest: compound 4; then compounds 1 and 2 (each within the scatter of the next); then compound 3.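

In this assay, the group on this carbonyl carbon proves a site of large change: hydroxy(phenyl)methyl in place of phenyl shifts the number strongly (a 95-fold lower number from compound 3 to compound 4 (1.98 log units; beyond the scatter)). The same group also gives lower numbers than either ring-substituted phenyl ester (a 7.4-fold lower number from compound 2 to compound 4 (0.87 log units; beyond the scatter); a 3.8-fold lower number from compound 1 to compound 4 (0.58 log units; beyond the scatter)), so this change reaches further down than the two aromatic substituents shown. No measurement here bears on the reason for this shift.

The compounds shown leave open whether the hydroxy or the added carbon carries the step. They also leave open how an amine or a carboxylic acid in place of that hydroxy would read.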